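Aryl for Benzylic Amine Swap in Hepatocyte Clearance

The source may report more compounds than this note shows. Statements on the series, on what has been measured and on what is new or still open speak of the compounds shown alone.

Compound 1 `C[C@@H](Nc1c(NCCCCCC(=O)NO)c(=O)c1=O)c1ccccc1` and compound 2 `C[C@H](Nc1c(NCCCCCC(=O)NO)c(=O)c1=O)c1ccccc1` share one core and differ only in configuration as drawn. In an ADME assay on cells (Hepatocyte, Homo sapiens) for pharmacokinetics, read by LC-MS, with a stated time of 90 min, tested at 1 uM (on this read-out higher numbers stand for fast clearance and lower numbers for slow clearance), compound 1 gives < 5 uL/min, which is a limit of the assay and not a number. Compound 2 gives < 5 uL/min in this assay, likewise a limit. The step that the two limits leave unreadable from compound 1 to compound 2 cannot be read, because of the limit of < 5 uL/min in this assay, at which 2 of the 2 values shown sit. Compound 2 therefore stands at the lowest reading the assay reports, with nothing beneath it to resolve.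

Compound 3 `Cc1ccc(Nc2c(NCCCCCC(=O)NO)c(=O)c2=O)cc1` is not yet measured. It differs from compound 2 by 4-methylphenyl in place of 1-phenylethyl on a nitrogen on an aromatic ring. For the measured compounds named here, the one measured step covers a change in configuration only and is itself unreadable, so no measured step bears on a swap of this kind, and there is no measured basis for any step beyond the scatter. With both measured compounds at the limit, compound 3 is expected to remain slow as well, an estimated step of a number no lower from compound 2 to compound 3 (the limit leaves the size open). Compound 3 is accordingly expected to give 5 uL/min in this assay, within a range from 2 uL/min to 15 uL/min.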

Compound 3, intrinsic clearance in a liver preparation (reported as CLH), per the amount of preparation that the assay uses: 7.2 uL/min
Estimate against measurement, compound 3: 1.4-fold (0.16 log units) below; the measured number falls inside the stated range.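

With 4-methylphenyl in place of 1-phenylethyl on a nitrogen on an aromatic ring, the series gains its first value that is a number and not a limit: compound 3 gives 7.2 uL/min in this assay. The swap also removes the one defined stereocentre, and the two configurations offer the same floor, with an at least 1.4-fold higher number from compound 2 to compound 3 (0.15 log units; that floor lies within the scatter) and an at least 1.4-fold higher number from compound 1 to compound 3 (0.15 log units; that floor lies within the scatter), so the true size may be larger, but nothing shown establishes a change beyond the scatter. The size of the swap stays open because the other two compounds give no number: the limit of < 5 uL/min in this assay, at which 2 of the 3 values shown sit.

The compounds shown leave open whether the reading of compound 3 belongs to the methyl group of 4-methylphenyl or to the aromatic ring itself standing on this nitrogen, a question that a plain phenyl or a benzyl group at the same place would help to separate. They also leave open how far clearance in this assay would move with a larger group on the ring, such as 4-methoxyphenyl or 4-chlorophenyl.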